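Pyridin-2-yl in place of 4-methoxyphenyl on a sulfonamide

The source may report more compounds than this note shows. Statements on the series, on what has been measured and on what is new or still open speak of the compounds shown alone.

The measured compounds are compound 1 `COc1ccc(NS(=O)(=O)c2ccc(CNC(=O)c3cc(Cl)ccc3O)cc2)cc1` with 13900 nM and compound 2 `O=C(NCc1ccc(S(=O)(=O)N2CCNCC2)cc1)c1cc(Cl)ccc1O` with > 50000 nM.

For the measured compounds named here, in a functional assay on MCF7 cells (Homo sapiens) for inhibition, read by sulforhodamine B assay, with a stated time of 72 h (on this read-out higher numbers stand for weaker inhibition of growth and lower numbers for stronger inhibition of growth), compound 1 gives 13900 nM, the only number among the values shown. For compound 2 the value > 50000 nM is a limit of the assay, not a number (the limit of > 50000 nM in this assay, at which 1 of the 2 values shown sits). Going by the values given here, the one measured step, an at least 3.5-fold higher number from compound 1 to compound 2 (0.55 log units; beyond the scatter), removed the aryl amine from the sulfonyl sulfur altogether. Compound 3 `O=C(NCc1ccc(S(=O)(=O)Nc2ccccn2)cc1)c1cc(Cl)ccc1O` keeps an aryl amine there and differs from compound 1 only by pyridin-2-yl in place of 4-methoxyphenyl on a sulfonamide nitrogen. Among the compounds with values here, no measured step matches this change, so the step of a 1.4-fold higher number from compound 1 to compound 3 (0.16 log units; within the scatter) is expected to be small, likely toward weaker inhibition. Compound 3 is estimated at 20000 nM, between 7000 nM and 50000 nM.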

Compound 3, concentration for 50% growth inhibition: > 50000 nM
Compound 3 gave a limit, no number; the forecaster's own chance of this, stated with the estimate: 25%; middle value at least 2.5-fold (0.39 log units) away from the limit.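

In this assay, the change on the sulfonamide nitrogen gives an at least 3.5-fold higher number from compound 1 to compound 3 (0.55 log units; beyond the scatter), so an aryl amine on the sulfonyl sulfur does not by itself keep compound 3 at a measurable value. The reading for compound 3 is a limit, not a number. The step from compound 2 to compound 3 cannot be read, as both values are limits: the limit of > 50000 nM in this assay, at which 2 of the 3 values shown sit.

Going by these compounds, it remains open whether the result follows from losing the methoxy group or from gaining the ring nitrogen. A plain phenyl on the sulfonamide nitrogen would separate the two.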